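Compound 4 Without the ((Phenylsulfonyl)amino)methyl Group

A few compounds are considered here, and "the series" means these few. Any claim that something is new, unique, unknown or untested is made for them only; others in the source may bear on it.

Compound 1 `CCCCc1ccc(CNS(=O)(=O)c2ccccc2)c(=O)n1Cc1ccc(-c2ccccc2-c2nn[nH]n2)cc1` is one of three compounds that share a core and differ only in the group on the saturated chain carbon bound to an aromatic carbon. In a functional assay (aorta) for antagonist activity, with Oryctolagus cuniculus as the target (a lower number here means a stronger inhibitor, a higher number a weaker inhibitor), compound 1 gives 7 nM, the second highest of the three numbers. Compound 2 `CCCCc1ccc(CN(C)S(=O)(=O)c2ccc(C)cc2)c(=O)n1Cc1ccc(-c2ccccc2-c2nn[nH]n2)cc1` gives 8 nM, and the step of a 1.1-fold higher number from compound 1 to compound 2 (0.06 log units; within the scatter) lies within the scatter. Compound 3 `CCCCc1ccc(CN(Cc2ccccc2)S(C)(=O)=O)c(=O)n1Cc1ccc(-c2ccccc2-c2nn[nH]n2)cc1` gives 2 nM, and the steps of a 3.5-fold lower number from compound 1 to compound 3 (0.54 log units; beyond the scatter) and a 4.0-fold lower number from compound 2 to compound 3 (0.60 log units; beyond the scatter) are modest. Compound 4 `CCCCc1cccc(=O)n1Cc1ccc(-c2ccccc2-c2nn[nH]n2)cc1` differs from compound 1 by hydrogen in place of ((phenylsulfonyl)amino)methyl on an aromatic carbon. For the measured compounds named here, none of the measured steps removes this group entirely; each only exchanges one such group for another, and those exchanges moved this assay by no more than a modest amount. The loss of the whole group is a larger change than any of those, so the number for compound 4 is expected to rise, probably beyond the scatter. Compound 4 is therefore estimated at 100 nM, with a range from 15 nM to 1000 nM, an expected step of a 14-fold higher number from compound 1 to compound 4 (1.15 log units; beyond the scatter).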

Compound 4, half-maximal inhibitory concentration: 4 nM
For compound 4 the middle estimate is 25-fold (1.40 log units) above the measured one; measured number below the stated range.
By their numbers in this assay, from the lowest: compounds 3, 4, 1 and 2 (each within the scatter of the next, the first and the last beyond it).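

Removing the whole ((phenylsulfonyl)amino)methyl group, with its 11 heavy atoms and its six-membered aromatic ring, and leaving hydrogen on this aromatic carbon gives a 1.8-fold lower number from compound 1 to compound 4 (0.24 log units; within the scatter) in this assay. The earlier compounds shown here only exchanged one sulfonamide-bearing group for another, so they could not show that this assay holds up with no substituent here at all: on the core of compound 1, this group is not required for a low nanomolar number. No evidence is available to explain this result.

The compounds shown leave open whether a smaller group on this carbon, such as a methyl, a plain aminomethyl or a carboxylic acid, would also leave the number within the scatter. They also leave open whether a substituent here can give a number clearly lower than that of compound 4.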